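Swapping Halogens on a Fused Ring: Expecting Compound 4

The source may report more compounds than this note shows. Statements on the series, on what has been measured and on what is new or still open speak of the compounds shown alone.

Compound 1 `CC#C[C@@H](CC(=O)O)c1ccc(OC[C@H]2COc3ccc(Cl)cc3O2)cc1`: 50 nM
Compound 2 `CC#C[C@@H](CC(=O)O)c1ccc(OC[C@H]2COc3ccc(F)cc3O2)cc1`: 210 nM
Compound 3 `CC#C[C@@H](CC(=O)O)c1ccc(OC[C@H]2COc3cc(F)c(Cl)cc3O2)cc1`: 210 nM

Of the compounds shown here, three have been tested in a functional assay on HEK293 cells for agonist activity at Free fatty acid receptor 1 (Homo sapiens), read by fluorescence and calcium flux, with a stated time of 10 min; on this read-out higher numbers stand for an effect only at larger amounts of compound and lower numbers for an effect already at smaller amounts. Compound 1 gives 50 nM, compound 2 gives 210 nM and compound 3 gives 210 nM, so compound 2 and compound 3 sit level with each other while compound 1 stands apart from both.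

Two single changes connect these numbers. The change from compound 2 to compound 1 is chloro in place of fluoro on an aromatic carbon, and it gave a 4.2-fold lower number from compound 2 to compound 1 (0.62 log units; beyond the scatter). From compound 1 to compound 3 a fluoro group enters in place of hydrogen, and this gave a 4.2-fold higher number from compound 1 to compound 3 (0.62 log units; beyond the scatter), wiping out the gain. The difference between the cores of compound 2 and compound 3 is not broken down here.

Compound 4 `CC#C[C@@H](CC(=O)O)c1ccc(OC[C@H]2COc3cc(Cl)c(Cl)cc3O2)cc1` is not yet measured. It differs from compound 3 by chloro in place of fluoro on an aromatic carbon. Among the compounds with values here, this is the same kind of change as the one from compound 2 to compound 1, though not the same: here the place is ortho to a chloro group (1 heavy atom), which is absent in the earlier pair.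

If the new change behaves like the earlier one, compound 4 is expected to improve on compound 3 by about a 3.5-fold lower number from compound 3 to compound 4 (0.54 log units; beyond the scatter), because compound 2 to compound 1 gave a 4.2-fold lower number from compound 2 to compound 1 (0.62 log units; beyond the scatter). Compound 4 is therefore estimated at 60 nM in this assay, with a plausible range from 20 nM to 180 nM.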

Compound 4, half-maximal effective concentration: 150 nM
Compound 4: middle estimate off by 2.5-fold (0.40 log units), on the low side, within the range that was stated.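

Chloro in place of fluoro on an aromatic carbon does not carry over at the same size from one core to the other in this series, as the two steps side by side show: the same change on two cores in this assay, a 4.2-fold lower number (0.62 log units; beyond the scatter) from compound 2 to compound 1 and a 1.4-fold lower number (0.15 log units; within the scatter) from compound 3 to compound 4, 3.0-fold (0.48 log units) apart, beyond the scatter of two such steps On the core that also bears a chloro group, the swap gives a 1.4-fold lower number from compound 3 to compound 4 (0.15 log units; within the scatter), so this pair cannot be told apart in this assay, while chloro in place of hydrogen gives a 3.0-fold higher number from compound 1 to compound 4 (0.48 log units; beyond the scatter), leaving that compound on the weaker side of the pair, as fluoro in place of hydrogen did with a 4.2-fold higher number from compound 1 to compound 3 (0.62 log units; beyond the scatter). These two pairs show that the size of the swap changed with the core here, but they do not show why it changed or what size it would have on any further core.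

Still open, as far as these compounds go, is how a bromo, methyl or nitrile group would compare with chloro and fluoro in the same place, ortho to a chloro group. From the compounds shown here alone, it is also open whether the swap would keep either size if an amide stood in place of the carboxylic acid, or if a different group replaced the chain that carries it.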